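The compounds below may be only part of what the source reports. "The series", "measured", "known", "first", "only" and "open" are said of these compounds alone.

Three ureas share one core and differ only on their second aromatic ring. In a physicochemical assay for solubility, at pH 7.4 (on this read-out lower numbers stand for lower solubility and higher numbers for higher solubility), compound 1 `Cc1cc(NC(=O)Nc2cccc(Cl)c2)c2ccccc2n1` gives 800 nM; compound 3 `Cc1cc(NC(=O)Nc2cc(Cl)cc(Cl)c2)c2ccccc2n1` gives 800 nM, and compound 2 `Cc1cc(NC(=O)Nc2ccc(F)cc2)c2ccccc2n1` gives 3700 nM. Compound 1 therefore stands level with compound 3 at the lowest number of the three, while a 4.6-fold higher number from compound 1 to compound 2 (0.67 log units; beyond the scatter) and no change at the digits printed from compound 1 to compound 3 (within the scatter). Compound 4 `Cc1cc(NC(=O)Nc2cccc(C(C)(C)C)c2)c2ccccc2n1` differs from compound 1 by tert-butyl in place of chloro on an aromatic carbon. Among the measured compounds shown here, no measured step removes a chloro or introduces a tert-butyl, so the nearest guide is the unchanged reading of compound 3, no change at the digits printed from compound 1 to compound 3 (within the scatter), which points to a small step at most. A modest step down is expected for compound 4, a 2.0-fold lower number from compound 1 to compound 4 (0.30 log units; within the scatter). Compound 4 is estimated at 400 nM, within 150 nM to 1500 nM.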

Compound 4, solubility: 34700 nM
The estimate for compound 4 lay 87-fold (1.94 log units) below the measured number; the measured number lies above the stated range.
By their numbers in this assay, from the lowest: compounds 1 and 3 (each within the scatter of the next); then compound 2; then compound 4.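

In this assay, the ring carbon that carries chloro in compound 1 proves highly sensitive, since tert-butyl in place of chloro gives a 43-fold higher number from compound 1 to compound 4 (1.64 log units; beyond the scatter) in a single change. The earlier step, no change at the digits printed from compound 1 to compound 3 (within the scatter) on adding a second chloro, left this chloro in place and so said little about replacing it. Nothing available explains the rise.

From the compounds shown here alone, whether it is special to tert-butyl stays open. Isopropyl, methyl or an amine at this carbon could show whether the number climbs gradually or only with tert-butyl.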